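Aryl sulfoxide variation at the sulfur of the shared core

The compounds below may be only part of what the source reports. "The series", "measured", "known", "first", "only" and "open" are said of these compounds alone.

Measured so far, in a functional assay on CWR22R cells (Homo sapiens) for antiproliferative activity; on this read-out higher numbers stand for weaker inhibition and lower numbers for stronger inhibition:
compound 1 `CC(O)(C[S+]([O-])c1ccc(C(F)(F)F)cn1)C(=O)Nc1ccc([N+](=O)[O-])cc1C(F)(F)F` — > 100000 nM; > 100000 nM (2 entries)
compound 2 `CC(O)(C[S+]([O-])c1ccc(F)cc1F)C(=O)Nc1ccc([N+](=O)[O-])cc1C(F)(F)F` — 51100 nM
compound 3 `CC(O)(C[S+]([O-])c1ccc(OC(F)(F)F)cc1)C(=O)Nc1ccc([N+](=O)[O-])cc1C(F)(F)F` — > 100000 nM

The value of compound 1 is a limit of the assay, not a number. Compound 2 gives a number in this assay. The value of compound 3 is again a limit of the assay; compound 3 thus stands at the limit of > 100000 nM in this assay, at which 1 of the 3 values shown sits, with no single number to anchor it. Among the compounds with values here, the only measured step that touches the aryl group on the sulfur is an at least 1.9-fold higher number from compound 2 to compound 3 (0.29 log units; that floor lies within the scatter), which moves from a number to a limit and whose floor lies within the scatter.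

Compound 4 `CC(O)(C[S+]([O-])c1ccccc1OC(F)(F)F)C(=O)Nc1ccc([N+](=O)[O-])cc1C(F)(F)F` differs from compound 3 by 2-(trifluoromethoxy)phenyl in place of 4-(trifluoromethoxy)phenyl on a sulfur. Within the data shown here, no measured step changes the position of a group on this aryl ring, so the step to compound 4 cannot be judged from a like-for-like precedent. Given that compound 3 sits at the limit, the step of a number no higher from compound 3 to compound 4 (the limit leaves the size open) is expected to be none beyond the scatter. Compound 4 is therefore expected to give about 100000 nM in this assay, within 40000 nM to 250000 nM, most likely reported again as a limit.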

Compound 4, half-maximal inhibitory concentration: 15200 nM
Compound 4: middle estimate off by 6.6-fold (0.82 log units), on the high side, and the stated range ends above it.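

In this assay, the position of the trifluoromethoxy group on the aryl ring matters, with the atoms unchanged: an at least 6.5-fold lower number from compound 3 to compound 4 (0.81 log units; beyond the scatter). Compared with the 2,4-difluorophenyl group, the 2-(trifluoromethoxy)phenyl group also gives a step beyond the scatter, a 3.4-fold lower number from compound 2 to compound 4 (0.53 log units; beyond the scatter), which is the first step at this sulfur that can be read as a real change. Compound 3 is a limit of the assay, so the first of these steps has only a floor: the limit of > 100000 nM in this assay, at which 1 of the 4 values shown sits.

The compounds shown do not tell whether the gain belongs to the trifluoromethoxy group itself or would also appear with another group in the same place, such as methoxy, chloro or an amine. From the compounds shown here alone, the effect of a pyridine ring carrying 2-(trifluoromethoxy) in place of the phenyl ring also remains open.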